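The compounds below may be only part of what the source reports. "The series", "measured", "known", "first", "only" and "open" are said of these compounds alone.

Compound 1, `COc1ccc2c(=O)c(/C=C/C(=O)NCc3ccccc3)coc2c1`, gives in a functional assay (QGY7701 cells, Homo sapiens) for inhibition, read by MTT assay, with a stated time of 48 h (a lower number here means a stronger inhibitor, a higher number a weaker inhibitor), the value > 100000 nM, which is a limit of the assay.
Compound 2, `CCOc1ccc(NC(=O)/C=C/c2coc3cc(OC)ccc3c2=O)cc1`, gives in this assay the value > 100000 nM, which is also a limit of the assay.
Compound 3, `COc1ccc2c(=O)c(/C=C/C(=O)Nc3ccccc3C)coc2c1`, gives in this assay the value 22500 nM.

Among the three, compound 3 stands out as the only one with a number in this assay; the other two sit at the limit of > 100000 nM in this assay, at which 2 of the 3 values shown sit. The step of an at least 4.4-fold lower number from compound 1 to compound 3 (0.64 log units; beyond the scatter) is the one that bears on the new compound, and it was at least modest; the step of an at least 4.4-fold lower number from compound 2 to compound 3 (0.64 log units; beyond the scatter) was of the same size, while the step that the two limits leave unreadable from compound 1 to compound 2 cannot be read from two limits.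

Compound 4, `COc1ccc2c(=O)c(/C=C/C(=O)NCc3ccc(F)cc3F)coc2c1`, differs from compound 3 in one place: 2,4-difluorobenzyl in place of 2-methylphenyl on an amide-type nitrogen. This change moves away from the 2-methylphenyl that gave compound 3 its number and back toward a benzyl-type group of the kind carried by compound 1. Since compound 1 sat at the limit of > 100000 nM in this assay, at which 2 of the 3 values shown sit, the step to compound 4 is expected to run in the direction of a higher number in this assay, with a real chance that only a limit is returned. For compound 4 the estimate in this assay is 60000 nM, within a range of 15000 nM to 150000 nM. The expected step of a 2.7-fold higher number from compound 3 to compound 4 (0.43 log units; beyond the scatter) is thus estimated to roughly undo the earlier gain.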

Compound 4, half-maximal inhibitory concentration: > 100000 nM
Compound 4: only a limit was reported; the forecaster's own chance of this, stated with the estimate: 50%; middle value at least 1.6-fold (0.22 log units) from the limit.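

The change from 2-methylphenyl to 2,4-difluorobenzyl on the amide-type nitrogen gave an at least 4.4-fold higher number from compound 3 to compound 4 (0.64 log units; beyond the scatter), so the number seen in this assay did not carry over to this group. Compound 1 had shown this only for an unsubstituted benzyl, whereas compound 4 shows that a benzyl ring carrying two fluorine atoms also gives no number, only a limit of the assay. Compound 3 therefore remains the only compound with a number at this position, while compound 1, compound 2 and compound 4 cannot be ranked against one another and the steps among them cannot be read: the limit of > 100000 nM in this assay, at which 3 of the 4 values shown sit.

The compounds shown do not tell whether the number of compound 3 depends on the methyl group itself or on the aromatic ring standing directly on the amide-type nitrogen, a question that a 2-methylbenzyl group or an unsubstituted phenyl group at this place would address. Going by these compounds, it also remains open how far the true values of the three compounds at the limit lie from one another, and whether a 2-chlorophenyl group would give a number in this assay.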